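This account rests on a few compounds, and the source may have more. Where it says the series, first, only, none or still open, it means among the compounds named here.

Values so far in a functional assay on HeLa cells (Homo sapiens) for cytotoxicity, read by MTT assay, with a stated time of 48 h; a higher number here means a weaker inhibitor, a lower number a stronger inhibitor
- compound 1 `COc1cc([C@H]2C[C@]2(CO)C(=O)Nc2ccccc2Cl)cc(OC)c1OC` gives 45500 nM
- compound 2 `COc1cc([C@H]2C[C@]2(CO)C(=O)NCc2ccc(C)cc2)cc(OC)c1OC` gives 57800 nM

Compound 2 stands level with compound 1, the two values lying within the scatter of each other (a 1.3-fold higher number from compound 1 to compound 2 (0.10 log units; within the scatter)). Compound 3 `COc1cc([C@H]2C[C@@]2(CO)C(=O)NCc2ccc(C)cc2)cc(OC)c1OC` has the same atoms and bonds as compound 2 and differs only in configuration as drawn (the two compounds have the same atoms and bonds and differ only in configuration as drawn: 1 of 2 stereo elements differ; a stereocentre at a saturated ring carbon is drawn S in compound 2 and R in compound 3). For the measured compounds named here, the one measured step replaces 2-chlorophenyl with 4-methylbenzyl on an amide-type nitrogen and leaves the drawn configuration alone. It therefore bears on this change only indirectly, showing that one change elsewhere in the series made no difference beyond the scatter (a 1.3-fold higher number from compound 1 to compound 2 (0.10 log units; within the scatter)). Going by the values given here, no measured pair differs in configuration, so the data give no direction for this change and no sign of its size. The working expectation in this assay is no step beyond the scatter, with wide margins on either side (a 1.1-fold lower number from compound 2 to compound 3 (0.02 log units; within the scatter)). For compound 3 the expected value is 55000 nM, with an estimated range from 22000 nM to 130000 nM.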

Compound 3, half-maximal inhibitory concentration: > 100000 nM
Compound 3 was reported as a limit; the forecaster's own chance of this, stated with the estimate: 15%; middle value at least 1.8-fold (0.25 log units) away from the limit.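

In this assay compound 3 gives > 100000 nM, which is a limit of the assay and not a number. The step reads an at least 1.7-fold higher number from compound 2 to compound 3 (0.23 log units; that floor lies within the scatter), so the change at the saturated ring carbon from S to R has a known direction in this pair: a lower number for the R form is not what was reported, though the floor of the step does not by itself separate the two compounds beyond the scatter. Unlike the earlier step on the amide-type nitrogen, this reading concerns configuration alone, with no group entering or leaving: the fact that compounds 2 and 3 differ only in the configuration as drawn.

On these data alone, how far compound 3 actually lies from compound 2 stays open, since only a floor is available, and so does the effect of the second stereo element, which is drawn the same in both compounds. Also open, as far as these compounds go, is whether the same change at the ring carbon reads alike with the 2-chlorophenyl of compound 1, or with an amine or a longer chain in place of 4-methylbenzyl on the amide-type nitrogen.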